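Swapping the thioester tail for an isopropyl thionocarbamate

The source may hold more compounds than are shown below. What is called first, only, known or untested is meant among the compounds shown, and "the series" means these compounds.

Compound 3 `Cc1nc(S(C)(=O)=O)ccc1Oc1ncnc(OC2CCN(C(=O)SC3CCC3)CC2)c1F` gives 8.51 nM in a functional assay on isolated protein for inhibition of Glucose-dependent insulinotropic receptor (Homo sapiens), read by HTRF and cAMP accumulation (on this read-out higher numbers stand for an effect only at larger amounts of compound and lower numbers for an effect already at smaller amounts), the second highest of the three numbers measured. Compound 2 `Cc1nc(S(C)(=O)=O)ccc1Oc1ncnc(OC2CCN(C(=O)SC(C)(C)C)CC2)c1F` gives 4.83 nM, and compound 1 `Cc1nc(S(C)(=O)=O)ccc1Oc1ncnc(OC2CCN(C(=O)OC(C)(C)CF)CC2)c1F` gives 19.9 nM. Compound 4 `Cc1nc(S(C)(=O)=O)ccc1Oc1ncnc(OC2CCN(C(=S)OC(C)C)CC2)c1F` differs from compound 3 by a group of 6 heavy atoms (4 carbon, 1 oxygen, 1 sulfur; no ring) in place of a group of 7 heavy atoms (5 carbon, 1 oxygen, 1 sulfur; one four-membered non-aromatic ring of carbon only), on an amine nitrogen in a ring. Among the measured compounds shown here, no measured step matches this change directly. The steps that touch the same tail are a 2.3-fold lower number from compound 1 to compound 3 (0.37 log units; beyond the scatter) and a 4.1-fold lower number from compound 1 to compound 2 (0.61 log units; beyond the scatter), both reached by putting a sulfur-linked group in place of an oxygen-linked one; compound 4 returns to an oxygen-linked group, so the number for compound 4 is expected to move back toward that of compound 1, giving a 1.5-fold higher number from compound 3 to compound 4 (0.18 log units; within the scatter). The estimate for compound 4 is 13 nM, with a range from 5 nM to 35 nM.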

Compound 4, half-maximal effective concentration: 69.9 nM
Estimate against measurement, compound 4: 5.4-fold (0.73 log units) below, and the stated range ends below it.
By their numbers in this assay, from the lowest: compounds 2 and 3 (each within the scatter of the next); then compound 1; then compound 4.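

On the ring nitrogen, the isopropyl thionocarbamate tail gives an 8.2-fold higher number from compound 3 to compound 4 (0.91 log units; beyond the scatter) and a 14-fold higher number from compound 2 to compound 4 (1.16 log units; beyond the scatter) and also a 3.5-fold higher number from compound 1 to compound 4 (0.55 log units; beyond the scatter) in the series. Compound 4 therefore has the highest number of the four rather than falling back near compound 1, so an oxygen-linked tail alone does not set the number. No measurement shown here explains this rise. Going by these compounds, what remains open is whether the thiocarbonyl or the isopropyl group accounts for the rise. An isopropyl carbamate, with a carbonyl in place of the thiocarbonyl, would separate the two.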